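The source may report more compounds than this note shows. Statements on the series, on what has been measured and on what is new or still open speak of the compounds shown alone.

Compound 1, `COc1ccc(-c2cc(/C=C/C(=O)c3ccc(OC)c(OC)c3)[nH]n2)cc1`: 1640 nM
Compound 2, `COc1ccc(-c2cc(/C=C/C(=O)c3cc(OC)c(OC)c(OC)c3)[nH]n2)cc1OC`: 1040 nM
Compound 3, `COc1ccc(C(=O)/C=C/c2cc(-c3cc(OC)c(OC)c(OC)c3)n[nH]2)cc1`: 1720 nM

These three compounds were all tested in a functional assay on NCI-H460 cells (Homo sapiens) for inhibition, read by sulforhodamine B assay, with a stated time of 48 h; on this read-out lower numbers stand for stronger inhibition of growth and higher numbers for weaker inhibition of growth. Among them compound 3 gives the highest of the three numbers, at 1720 nM, but its nearest neighbour, compound 1, and its furthest neighbour, compound 2, both lie within the scatter of it, so the three cannot be ranked against one another on this read-out.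

Compound 4, `COc1cc(-c2cc(/C=C/C(=O)c3ccc(F)c(F)c3)[nH]n2)cc(OC)c1OC`, follows from compound 3 by a single change: 3,4-difluorophenyl in place of 4-methoxyphenyl on a carbonyl carbon. Among the compounds with values here, no pair of measured compounds shows this exchange, so there is no step in this assay to lean on. Given that compound 3 stands at 1720 nM and that nothing among the measured compounds speaks for a shift in either direction, the step from compound 3 to compound 4 is expected to be small, a 1.2-fold higher number from compound 3 to compound 4 (0.07 log units; within the scatter), and not to exceed the scatter. Compound 4 is therefore estimated at 2000 nM in this assay, with a range from 800 nM to 5000 nM.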

Compound 4, concentration for 50% growth inhibition: 2960 nM
Beside the measured number, compound 4's estimate is 1.5-fold (0.17 log units) below it; the range from low to high includes it.
By their numbers in this assay, from the lowest: compounds 2, 1, 3 and 4 (each within the scatter of the next, the first and the last beyond it).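

In this assay, within the data shown here, the exchange of 4-methoxyphenyl for 3,4-difluorophenyl on a carbonyl carbon gives a 1.7-fold higher number from compound 3 to compound 4 (0.24 log units; within the scatter), and this is the first comparison in which only one place differs. On this single pair, the read-out does not separate the two aryl groups, so replacing the methoxy-bearing ring with the difluorinated one, of equal heavy-atom count, leaves no change that can be told from the scatter. Nothing available bears on this result or offers an account of it.

Among these compounds, whether the same holds for this exchange on another version of the shared core remains open, since this one pair is the only reading of it. Also open, going by these compounds, is how an aminophenyl group or a carboxylic acid would read in this place on a carbonyl carbon.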